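Working notes on a biaryl urea series: compound 3

The compounds below may be only part of what the source reports. "The series", "measured", "known", "first", "only" and "open" are said of these compounds alone.

Measured so far:
compound 1, `CC(C)c1cccc(C(C)C)c1NC(=O)Nc1nc2ccccc2n1-c1ccc(Cl)cc1` — in an assay on isolated protein for displacement of a labelled ligand from acyl-CoA:cholesterol acyltransferase (Oryctolagus cuniculus) (a lower number here means a stronger inhibitor, a higher number a weaker inhibitor), compound 1 gives 280 nM
compound 2, `CC(C)c1cccc(C(C)C)c1NC(=O)Nc1nc2ccccc2n1-c1ccccc1Br` — in this assay compound 2 gives 22 nM

Among the compounds with values here, compound 1 stands at the highest of the two numbers; its only neighbour is compound 2, reached by a 13-fold lower number from compound 1 to compound 2 (1.10 log units; beyond the scatter). The next compound, compound 3, `CC(C)c1cccc(C(C)C)c1NC(=O)Nc1nc2ccccc2n1-c1c(Cl)cccc1Cl`, has not been measured. Its change from compound 1 is this: 2,6-dichlorophenyl in place of 4-chlorophenyl on an aromatic nitrogen. Within the data shown here, the one measured step that bears on this change is a 13-fold lower number from compound 1 to compound 2 (1.10 log units; beyond the scatter), in which 2-bromophenyl replaced 4-chlorophenyl at the same ring nitrogen and the number fell by a large amount. Compound 3 carries chlorine at the 2 and 6 positions of that phenyl, so a lower number than compound 1 is expected, a step of roughly a 9.3-fold lower number from compound 1 to compound 3 (0.97 log units; beyond the scatter), with the caution that a single measured step is a thin basis. Compound 3 is therefore estimated at 30 nM in this assay, with a range from 8 nM to 120 nM.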

Compound 3, half-maximal inhibitory concentration: 11 nM
Estimate against measurement, compound 3: 2.7-fold (0.44 log units) above; low and high end bracket the measured number.
By their numbers in this assay, from the lowest: compounds 3 and 2 (each within the scatter of the next); then compound 1.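

The large fall at this ring nitrogen is not confined to bromine: in this assay, 2,6-dichlorophenyl in place of 4-chlorophenyl gives a 25-fold lower number from compound 1 to compound 3 (1.41 log units; beyond the scatter) and so joins 2-bromophenyl in the low range. Between the two, a 2.0-fold lower number from compound 2 to compound 3 (0.30 log units; within the scatter) leaves compounds 2 and 3 unordered, and a second halogen shows no separable gain, since chlorine for bromine and the added chlorine change together in this step. Nothing measured on these compounds accounts for the difference from 4-chlorophenyl.

The compounds shown leave open whether a halogen is needed at all, which 2-methylphenyl or 2-methoxyphenyl on the same nitrogen would address. Unsubstituted phenyl and 2-chlorophenyl would show whether 4-chlorophenyl raises the number or the other groups lower it, and what one chlorine alone contributes.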